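The source may report more compounds than this note shows. Statements on the series, on what has been measured and on what is new or still open speak of the compounds shown alone.

Working notes on the series. Among the compounds with values here, the shared core is that of compound 1 `CCCNC(=O)c1cc(Oc2ccc(NC(=O)c3cc4cccnc4n(-c4ccccc4F)c3=O)cc2)ccn1`, which in a functional assay on U-87MG ATCC cells for antiproliferative activity against U-87 MG (Homo sapiens), read by MTT assay, with a stated time of 72 h (on this read-out higher numbers stand for weaker inhibition and lower numbers for stronger inhibition), gives 2320 nM; this is the only number in hand for the set. Compound 2 `CCCNC(=O)c1cc(Oc2ccc(NC(=O)c3cc4cccnc4n(-c4ccc(Cl)cc4)c3=O)cc2)ccn1` carries a 4-chlorophenyl in place of the 2-fluorophenyl of compound 1, and in this assay compound 2 gives "not determined" (no result reported), so no result is available for it and it cannot be placed against compound 1 on the numbers shown. Compound 3 `CCCNC(=O)c1cc(Oc2ccc(NC(=O)c3cc4cccnc4n(-c4ccc(Br)cc4)c3=O)cc2)ccn1` has not yet been measured in this assay. The change from compound 2 to compound 3 is bromo in place of chloro on an aromatic carbon, para to a large group; the halogen swap leaves the rest of the molecule unchanged. Within the data shown here, no step between measured compounds is on hand, and for a swap of this kind the expectation in this assay is a step of no more than the usual scatter, with no firm direction. Taking the single known value, that of compound 1, as the anchor, compound 3 is expected in this assay at about 2500 nM, with a range of 800 nM to 8000 nM.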

Compound 3, half-maximal inhibitory concentration: 5190 nM
Compound 3: middle estimate off by 2.1-fold (0.32 log units), on the low side, within the range that was stated.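

On this assay the group on the aromatic nitrogen now has a first reading: 4-bromophenyl in place of 2-fluorophenyl gives a 2.2-fold higher number from compound 1 to compound 3 (0.35 log units; beyond the scatter) and so shows that this position can move the read-out, though only by a modest step. That step changes the halogen and its place on the ring together, so it cannot be assigned to either one alone, and the chloro to bromo change itself cannot be read, since compound 2 has no result to set against compound 3. No measurement on hand bears on why the number moves in this direction.

Still open, as far as these compounds go, is whether halogen identity or halogen place carries the step, a question that 4-fluorophenyl, 2-bromophenyl or unsubstituted phenyl on the same nitrogen would address. Also open, from the compounds shown here alone, is how the position responds to groups of a different kind, such as a phenyl bearing an amine or a carboxylic acid, or a plain alkyl chain in place of the aromatic ring.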